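The source may report more compounds than this note shows. Statements on the series, on what has been measured and on what is new or still open speak of the compounds shown alone.

Within the data shown here, in a functional assay on a cell-free system (Platelet, plasma, Homo sapiens) for inhibition, read by turbidimetry, with a stated time of 3 min (on this read-out lower numbers stand for stronger inhibition and higher numbers for weaker inhibition), compound 1 `CS(=O)(=O)c1ccc(-n2nc(C(=O)N3CCCCC3)cc2-c2ccc(Cl)cc2)nn1` gives 19600 nM, the only actual number so far. Compound 2 `CS(=O)(=O)c1ccc(-n2nc(C(=O)N3CCOCC3)cc2-c2ccc(Cl)cc2)nn1` reads > 20000 nM, which is a limit of the assay and not a number. The evidence therefore centres on (the limit of > 20000 nM in this assay, at which 1 of the 2 values shown sits).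

The next analogue, compound 3 `COc1ccc(-n2nc(C(=O)N3CCCCC3)cc2-c2ccc(Cl)cc2)cc1`, keeps the core and the (piperidin-1-yl)carbonyl group of compound 1, with 4-methoxyphenyl in place of 6-(methylsulfonyl)pyridazin-3-yl on an aromatic nitrogen. Among the measured compounds shown here, the one measured step, an at least 1.0-fold higher number from compound 1 to compound 2 (0.00 log units; that floor lies within the scatter), lies on a carbonyl carbon, not at this aromatic nitrogen, and stays within the scatter, so it gives no size for the present change. For the measured compounds named here, no measured step touches this place.

With compound 1 at 19600 nM, little room remains for a higher number in this assay, so only a modest move toward stronger inhibition could be read. Another limit reading remains quite possible for compound 3. The expected change is a 2.0-fold lower number from compound 1 to compound 3 (0.29 log units; within the scatter). For compound 3 the estimate is 10000 nM, with an expected range from 2000 nM to 20000 nM.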

Compound 3, half-maximal inhibitory concentration: 7.9 nM
Compound 3: the middle estimate sits 1300-fold (3.10 log units) above what was measured, and the stated range ends above it.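

In this assay, among these compounds, the group on the aromatic nitrogen is the first place where a change moves the read-out beyond the scatter: 4-methoxyphenyl in place of 6-(methylsulfonyl)pyridazin-3-yl gives a 2500-fold lower number from compound 1 to compound 3 (3.39 log units; beyond the scatter). The shared core, the 4-chlorophenyl group and the (piperidin-1-yl)carbonyl group are the same in the pair, so this whole step belongs to this one place, and the series is clearly not flat there. The earlier compounds shown here could show no such spread, since compound 2 stays a limit and not a number: the limit of > 20000 nM in this assay, at which 1 of the 3 values shown sits.

The swap replaces the whole aromatic group, so the step cannot be divided among the loss of the ring nitrogens, the loss of the methylsulfonyl group and the gain of the methoxy group; a plain phenyl or a 4-(methylsulfonyl)phenyl group on the same nitrogen would separate these parts. Among the compounds shown here, also open is whether morpholin-4-yl in place of piperidin-1-yl on the carbonyl carbon matters once 4-methoxyphenyl sits on the nitrogen, as the only reading of that change lies at the top of the assay range.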